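Working notes: from compound 3 to compound 4

This account rests on a few compounds, and the source may have more. Where it says the series, first, only, none or still open, it means among the compounds named here.

Values in a functional assay for inhibition, with Sus scrofa as the target; a higher number here means a weaker inhibitor, a lower number a stronger inhibitor
- compound 1 `CC1(C)Oc2ccc(C#N)cc2[C@@H](Oc2ccccn2)[C@]1(C)O` gives 6000 nM
- compound 2 `CC1(C)Oc2ccc(C#N)cc2[C@@H](N2CCCC2=O)[C@]1(C)O` gives 4000 nM
- compound 3 `CC1(C)Oc2ccc(C#N)cc2[C@@H](Nn2ccccc2=O)[C@]1(C)O` gives > 100000 nM as a limit, not a number

Compound 3 sits at the top of the numbers shown (the limit of > 100000 nM in this assay, at which 1 of the 3 values shown sits). Compound 4 `CC1(C)Oc2ccc(C#N)cc2[C@@H](Oc2ccc(=O)[nH]n2)[C@]1(C)O` is still unmeasured and differs from compound 3 as follows (a group of 8 heavy atoms (4 carbon, 2 nitrogen, 2 oxygen; one six-membered aromatic ring with 2 hetero atoms) in place of a group of 8 heavy atoms (5 carbon, 2 nitrogen, 1 oxygen; one six-membered aromatic ring with 1 hetero atom), on a saturated ring carbon). Two large measured steps bear on this change (an at least 16-fold higher number from compound 1 to compound 3 (1.22 log units; beyond the scatter)) (an at least 25-fold higher number from compound 2 to compound 3 (1.39 log units; beyond the scatter)). Compound 4 shares with compound 1 an aromatic ring attached through oxygen, and the remaining step lies within the scatter (a 1.5-fold lower number from compound 1 to compound 2 (0.18 log units; within the scatter)). A large step to a lower number is therefore expected (an at least 40-fold lower number from compound 3 to compound 4 (1.60 log units; beyond the scatter)). In this assay compound 4 is estimated at 2500 nM (expected range 400 nM to 20000 nM).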

Compound 4, half-maximal inhibitory concentration: 6 nM
Compound 4: the middle estimate sits 420-fold (2.62 log units) above what was measured; the whole stated range lies above it.
By their numbers in this assay, from the lowest: compound 4; then compounds 2 and 1 (each within the scatter of the next). At a limit, above all of these: compound 3.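

In this assay, keeping the link through oxygen and changing only the aromatic ring on it gives a 1000-fold lower number from compound 1 to compound 4 (3.00 log units; beyond the scatter), so this position responds far more strongly than compounds 1 and 2, which lie within the scatter of each other, had suggested. Against the 2-oxopyrrolidin-1-yl group, the result is a 670-fold lower number from compound 2 to compound 4 (2.82 log units; beyond the scatter). The step of an at least 16000-fold lower number from compound 3 to compound 4 (4.22 log units; beyond the scatter) starts from a limit, not a number: the limit of > 100000 nM in this assay, at which 1 of the 4 values shown sits.

The compounds shown leave open whether the second ring nitrogen or the carbonyl carries the change, since the two arrive together. A methoxy group or an amine in place of that carbonyl would separate them.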